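A few compounds are considered here, and "the series" means these few. Any claim that something is new, unique, unknown or untested is made for them only; others in the source may bear on it.

Working notes on the series.

Compound 1 `CCCn1c(=O)n(CC)c(=O)c2[nH]cnc21` gives 1400 nM in an assay on membranes from brain for displacement of a labelled ligand from adenosine receptor A1 (Cavia porcellus); on this read-out lower numbers stand for stronger inhibition and higher numbers for weaker inhibition. Compound 2 `CCCn1c(=O)n(CC)c(=O)c2c1ncn2C` gives 11800 nM in this assay, and the step of an 8.4-fold higher number from compound 1 to compound 2 (0.93 log units; beyond the scatter) is a (methyl in place of hydrogen on an aromatic nitrogen). Compound 3 `CCCCn1cnc2c1c(=O)[nH]c(=O)n2CCC` gives 12100 nM in this assay; its value and that of compound 2 lie within the scatter of each other, while the gap to compound 1 is beyond it. The difference between the cores of compound 1 and compound 3 is not broken down here.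

Compound 4 `CCCCn1cnc2c1c(=O)n(C)c(=O)n2CCC` is not yet measured in this assay. It differs from compound 3 by methyl in place of hydrogen on an aromatic nitrogen, the same kind of change as from compound 1 to compound 2, but at another place: on a six-membered rather than a five-membered aromatic ring, ortho to two groups of 1 heavy atom each and meta to a propyl group. Among the compounds with values here, the only measured step of this kind is at a different place, so the expectation rests loosely on it: the step of a 2.4-fold lower number from compound 3 to compound 4 (0.38 log units; beyond the scatter) is expected, with wide uncertainty. For compound 4 the estimate is 5000 nM, between 1200 nM and 20000 nM.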

Compound 4, inhibition constant: 7300 nM
Beside the measured number, compound 4's estimate is 1.5-fold (0.16 log units) below it; measured number inside the range.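

Methyl in place of hydrogen on an aromatic nitrogen gives a 1.7-fold lower number from compound 3 to compound 4 (0.22 log units; within the scatter), so on this core the change stays within the scatter, unlike the step on the core of compound 1. The change therefore does not carry over as a fixed step from one core to another in this assay: the same change on two cores in this assay, an 8.4-fold higher number (0.93 log units; beyond the scatter) from compound 1 to compound 2 and a 1.7-fold lower number (0.22 log units; within the scatter) from compound 3 to compound 4, 14-fold (1.15 log units) apart, beyond the scatter of two such steps

This does not show what sets the two steps apart: the methyl sits on a five-membered aromatic ring in compound 2 and on a six-membered aromatic ring in compound 4, and the cores differ as well, so place and core cannot be separated, and two steps give no rule for the series.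

Open, as far as these compounds go, is how the six-membered ring nitrogen of compound 3 responds to groups other than methyl, such as a benzyl group, a longer chain or a chain ending in an amine or a carboxylic acid. Also open, from the compounds shown here alone, is whether the step seen from compound 1 to compound 2 recurs on a further core with a hydrogen on the five-membered ring nitrogen.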